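The source may hold more compounds than are shown below. What is called first, only, known or untested is meant among the compounds shown, and "the series" means these compounds.

Measured compounds:
compound 1 `CCC(=O)N1CCc2nc(C#Cc3ccccc3)sc2C1` — an assay on HEK293 cells for positive allosteric modulation of metabotropic glutamate receptor 5 (Homo sapiens), read by FLIPR, with a stated time of 1 h; on this read-out higher numbers stand for an effect only at larger amounts of compound and lower numbers for an effect already at smaller amounts: > 10000 nM
compound 2 `O=C(C1CCC(F)(F)CC1)N1CCc2nc(C#Cc3ccccc3)sc2C1` — this assay: 70 nM

Compound 2 stands with the only number shown in this assay, the other value being a limit (the limit of > 10000 nM in this assay, at which 1 of the 2 values shown sits). For compound 1 the result > 10000 nM is a limit of the assay and not a number. Compound 3 `CC1CCCC(C(=O)N2CCc3nc(C#Cc4ccccc4)sc3C2)C1` is not yet measured; it differs from compound 2 in that (3-methylcyclohexyl in place of 4,4-difluorocyclohexyl on a carbonyl carbon). Among the measured compounds shown here, one measured step bears on the same carbonyl carbon, namely an at least 140-fold lower number from compound 1 to compound 2 (2.15 log units; beyond the scatter), where ethyl gave way to a six-membered ring; compound 3 keeps a six-membered ring, so only a modest shift in this assay is expected, most likely toward a somewhat higher number. Compound 3 is therefore estimated at 120 nM, within a range from 30 nM to 600 nM, which means an expected step of a 1.7-fold higher number from compound 2 to compound 3 (0.23 log units; within the scatter).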

Compound 3, half-maximal effective concentration: 100 nM
Compound 3: the middle estimate sits 1.2-fold (0.08 log units) above what was measured, and the stated range covers the measured number.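

In this assay, the step of a 1.4-fold higher number from compound 2 to compound 3 (0.15 log units; within the scatter) leaves the two compounds indistinguishable, so on this carbonyl carbon the fluorine atoms of 4,4-difluorocyclohexyl are not required and a six-membered carbon ring carrying a methyl group serves equally well. A second such ring in place of ethyl also gives a large change, an at least 100-fold lower number from compound 1 to compound 3 (2.00 log units; beyond the scatter), so in both compounds 2 and 3 the change from ethyl goes the same way, with neither going against it. This step is a bound and not an exact size, as compound 1 stands at a limit of the assay: the limit of > 10000 nM in this assay, at which 1 of the 3 values shown sits.

As far as these compounds go, whether a longer open chain, a smaller cyclopropyl ring or an aromatic phenyl ring on the same carbonyl carbon would keep such numbers remains open. So does whether a six-membered ring bearing an amine or a carboxylic acid would do so.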